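Vero cytotoxicity notes: removing one chloro from compound 1

The source may hold more compounds than are shown below. What is called first, only, known or untested is meant among the compounds shown, and "the series" means these compounds.

Of the compounds shown here, three with a shared core have been measured. In an ADME assay on Vero cells (Chlorocebus sabaeus) for cytotoxicity, read by neutral red uptake, tested at 98 ug/mL (on this read-out higher numbers stand for a weaker effect at the one concentration tested and lower numbers for a stronger effect), compound 1 `O=C1CSC(c2c(Cl)cccc2Cl)N1CCN1CCCCC1` gives 76%. Compound 2 `O=C1CSC(c2ccc(O)cc2)N1CCN1CCCCC1` gives 94% in this assay, and compound 3 `COc1ccccc1C1SCC(=O)N1CCN1CCCCC1` gives 100%. Compound 1 thus stands lowest of the three numbers, with compound 2 nearest, beyond the scatter above it, and compound 3 furthest, also beyond the scatter. Compound 4 `O=C1CSC(c2ccccc2Cl)N1CCN1CCCCC1` is not yet measured; it differs from compound 1 by hydrogen in place of chloro on an aromatic carbon. Going by the values given here, no single-change step between measured compounds exists to guide the size. A modest step upward in this assay is expected, near the edge of the scatter. For compound 4 the estimate is 85%, between 70% and 100%. The expected step is a number 9 percentage points higher from compound 1 to compound 4 (within the scatter).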

Compound 4, a percentage reported as activity, at one concentration (the size of the read-out at that concentration, not a potency): 94%
For compound 4 the middle estimate is 9 percentage points below the measured one, within the range that was stated.
By their numbers in this assay, from the lowest: compound 1; then compounds 2, 4 and 3 (each within the scatter of the next).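

In this assay, removing one chloro from this aromatic carbon gives a number 18 percentage points higher from compound 1 to compound 4 (beyond the scatter), so the lowest number in the set depends on this second chloro. With one chloro left, the compound no longer stands apart from the others: a number 6 percentage points lower from compound 3 to compound 4 (within the scatter) for chloro in place of methoxy, and no change at the digits printed from compound 2 to compound 4 (within the scatter) for 2-chlorophenyl in place of 4-hydroxyphenyl. No measurement at hand accounts for the step.

Open, from the compounds shown here alone, is whether a fluoro or a methyl on this carbon would act as the chloro does, and whether the step depends on the remaining chloro.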